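Fluoro to Methoxy: An Expectation for Compound 3

A few compounds are considered here, and "the series" means these few. Any claim that something is new, unique, unknown or untested is made for them only; others in the source may bear on it.

Compound 1 `N#Cc1cnn(-c2ccc(S(N)(=O)=O)cc2)c1NC(=O)CCl`: 67.5%
Compound 2 `N#Cc1cnn(-c2ccc(S(N)(=O)=O)cc2)c1/N=C/c1ccc(F)cc1`: 73.9%

Of the compounds shown here, two have been measured in a functional assay on the whole organism for inhibition, with Rattus norvegicus as the target, read by immunoassay and paw edema, in plasma, with stated times of 1 h and 2 h, at a dose of 10 umol/kg by the subcutaneous route; on this read-out higher numbers stand for more inhibition at the one dose given (going by the name of the read-out) and lower numbers for less inhibition. Compound 1, which carries a chloroacetamide on the shared core, gives 67.5%. Compound 2, bearing an imine to a 4-fluorophenyl group instead, gives 73.9%. Compound 2 stands highest of the two numbers, but its nearest neighbour, compound 1, lies within the scatter of it, so the two cannot be placed in any order of inhibition.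

The next compound, compound 3 `COc1ccc(/C=N/c2c(C#N)cnn2-c2ccc(S(N)(=O)=O)cc2)cc1`, differs from compound 2 at one place: methoxy in place of fluoro on an aromatic carbon. Within the data shown here, no step between two measured compounds tells how such a change acts on this read-out. With nothing to draw on beyond the two values shown, no step beyond the scatter is expected in this assay, in either direction.

Compound 3 is therefore estimated to give 70%, with a range from 55% to 85%, which corresponds to an expected step of a number 3.9 percentage points lower from compound 2 to compound 3 (within the scatter).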

Compound 3, a percentage reported as inhibition, in the whole organism at one dose (the size of the read-out at that dose, not a potency): 64.4%
Estimate against measurement, compound 3: 5.6 percentage points above; the measured number falls inside the stated range.
By their numbers in this assay, from the lowest: compounds 3, 1 and 2 (each within the scatter of the next).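

In this assay, among these compounds, the exchange of 4-fluorophenyl for 4-methoxyphenyl gives the first step between two compounds that differ in one place (a number 9.5 percentage points lower from compound 2 to compound 3 (within the scatter)). At this position, on an aromatic carbon para to a large group, fluoro can thus give way to the methoxy group, with its additional heavy atom and its hydrogen-bond acceptor, without a step beyond the scatter on this read-out, although this rests on a single pair. Nothing available explains the size of this step or links it to any property of either group.

The compounds shown hold only fluoro and methoxy at this position, so it remains open whether an amine, a carboxylic acid or a longer chain such as butoxy placed there would give a step beyond the scatter. They also leave open whether the same exchange would read the same way with a different link between the shared core and the aromatic ring, as the imine is the only such link present in this pair.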